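The source may report more compounds than this note shows. Statements on the series, on what has been measured and on what is new or still open speak of the compounds shown alone.

Working notes on the series. In a functional assay on HepG2 cells (Homo sapiens) for cytotoxicity, read by sulforhodamine B assay, with a stated time of 48 h (on this read-out lower numbers stand for stronger inhibition and higher numbers for weaker inhibition), compound 3 `Cc1ccc(S(=O)(=O)Nc2ccc(C(=O)/C=C/c3ccc(Cl)cc3)cc2)cc1` gives 43300 nM. Among the three measured compounds this is the second highest number: compound 2 `Cc1ccc(S(=O)(=O)Nc2ccc(-c3cc(-c4ccc([N+](=O)[O-])cc4)[nH]n3)cc2)cc1` gives 44800 nM, a number that sits within the scatter of compound 3, and compound 1 `C/C(=N/n1c(N)cc(N)c(C#N)c1=O)c1ccc(NS(=O)(=O)c2ccccc2)cc1` gives 25500 nM, a lower number that also stays within the scatter of compound 3. For the measured compounds named here, all three therefore read as weak in this assay, with no compound separated from the others beyond the scatter.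

Compound 4 `Cc1ccc(S(=O)(=O)Nc2ccc(C(=O)/C=C/c3ccc([N+](=O)[O-])cc3)cc2)cc1` follows from compound 3 by one change: nitro in place of chloro on an aromatic carbon. Going by the values given here, no step between measured compounds covers this exchange. Compound 2 carries a nitro on a phenyl ring and gives 44800 nM, which gives no sign that the group moves the number far. The step from compound 3 to compound 4 is expected to be a 1.1-fold lower number from compound 3 to compound 4 (0.03 log units; within the scatter), none beyond the scatter. Compound 4 is estimated at 40000 nM, with a range from 15000 nM to 100000 nM.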

Compound 4, half-maximal inhibitory concentration: 26000 nM
The estimate for compound 4 lay 1.5-fold (0.19 log units) above the measured number; low and high end bracket the measured number.
By their numbers in this assay, from the lowest: compounds 1, 4, 3 and 2 (each within the scatter of the next).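

For the compounds shown here, the exchange of 4-chlorophenyl for 4-nitrophenyl gives the first direct reading at this position: this assay shows a 1.7-fold lower number from compound 3 to compound 4 (0.22 log units; within the scatter) for this change, so nitro and chloro are not told apart here. Both groups, on an aromatic carbon para to a large group, leave the number in the same weak range of the series. Nothing available bears on any cause for this.

Going by these compounds, whether an amine or a carboxylic acid at this position would move the number beyond the scatter stays open. So does whether any change to the shared core would do so.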